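A few compounds are considered here, and "the series" means these few. Any claim that something is new, unique, unknown or untested is made for them only; others in the source may bear on it.

Compound 1, `CCOC(=O)c1sc2nc(SC)nc(-c3cccc(OC)c3)c2c1N`, was tested in a functional assay on HEK293 cells for agonist activity at Thyrotropin receptor (Homo sapiens), read by cAMP accumulation (a lower number here means a smaller maximal response, a higher number a larger maximal response), where compound 1 gives 1.5%. Among the measured compounds shown here, the only other number in the set comes from compound 2, `CSc1nc(-c2cccc(F)c2)c2c(N)c(C(=O)NC(C)(C)C)sc2n1`, which in this assay gives 8.1%. The two numbers lie within the scatter of each other, so nothing separates compound 1 from compound 2 on this read-out; both give a small maximal response, and compound 1 has the lower of the two numbers by a margin that means nothing.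

Compound 3, `COc1cccc(-c2nc(SC)nc3sc(C(=O)NN)c(N)c23)c1`, has not yet been measured. It differs from compound 1 in one place: aminoamino in place of ethoxy on a carbonyl carbon. Compound 2 already carries a carbamoyl group rather than an ester at the same carbonyl, and its maximal response remains small, which is the only hint the data give for a change at this carbonyl.

For the measured compounds named here, with no step between measured compounds to go by, the expectation for compound 3 in this assay is a step of a number 3.5 percentage points higher from compound 1 to compound 3 (within the scatter), nothing beyond the scatter. Compound 3 is therefore estimated at 5%, with a range from -5% to 20%.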

Compound 3, largest response reached (reported as efficacy), in percent of the reference or control that the assay uses: 6.1%
For compound 3 the middle estimate is 1.1 percentage points below the measured one, within the range that was stated.
By their numbers in this assay, from the lowest: compounds 1, 3 and 2 (each within the scatter of the next).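

Among the compounds shown here, this is the first direct reading of a single change on this carbonyl carbon: in this assay, aminoamino in place of ethoxy gives a number 4.6 percentage points higher from compound 1 to compound 3 (within the scatter), so this exchange does not separate the two compounds on maximal response. Leaving ethoxy for aminoamino changes the count of hydrogen-bond donors on this carbonyl from 0 to 2, yet the response stays small, and the earlier hint from compound 2 could not show this because that compound differs from compound 1 in more than one place. No measured evidence on the cause of this result is available here, and with a step inside the scatter there is no effect to explain.

On these data alone, what remains open is whether any group on this carbonyl carbon can raise the maximal response beyond the scatter, for example a carboxylic acid, an unsubstituted amide or an ester with a longer chain. The compounds shown also leave open whether aminoamino and ethoxy would remain indistinguishable on a core carrying a different group in place of the 3-methoxyphenyl ring.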